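The compounds below may be only part of what the source reports. "The series", "measured", "known", "first", "only" and "open" are said of these compounds alone.

Going by the values given here, compound 3 `Cn1cc(C2=C(c3nn(CCCN4CCCCC4)c4ncccc34)C(=O)N(c3ccccc3)C2=O)c2ccccc21` gives 5600 nM in a functional assay on KB cells (Homo sapiens) for antiproliferative activity, read by MTT assay, with a stated time of 48 h (on this read-out higher numbers stand for weaker inhibition and lower numbers for stronger inhibition), the only actual number among the three values shown. Compound 1 `Cn1cc(C2=C(c3nn(CCn4ccnc4)c4ncccc34)C(=O)NC2=O)c2ccccc21` reaches only the limit of > 100000 nM in this assay. Compound 2 `Cn1cc(C2=C(c3nn(CCCn4cccc4)c4ncccc34)C(=O)N(c3ccccc3)C2=O)c2ccccc21` likewise stops at the limit of > 100000 nM. Among the compounds with values here, the single measured step bearing on the change, an at least 17-fold lower number from compound 2 to compound 3 (1.25 log units; beyond the scatter), started from that limit (the limit of > 100000 nM in this assay, at which 2 of the 3 values shown sit). Compound 4 `Cn1cc(C2=C(c3nn(CCn4ccnc4)c4ncccc34)C(=O)N(c3ccccc3)C2=O)c2ccccc21` differs from compound 3 by 1H-imidazol-1-yl in place of (piperidin-1-yl)methyl on a saturated chain carbon, two bonds along the chain from an aromatic nitrogen. A large rise in this assay is expected for compound 4, since an at least 17-fold lower number from compound 2 to compound 3 (1.25 log units; beyond the scatter) was large for the reverse kind of swap, from a five-membered aromatic ring to piperidin-1-yl. Compound 4 is therefore estimated at 100000 nM, ranging from 20000 nM to 300000 nM, quite possibly reported only as a limit. That amounts to an expected step of an 18-fold higher number from compound 3 to compound 4 (1.25 log units; beyond the scatter).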

Compound 4, half-maximal inhibitory concentration: > 100000 nM
Compound 4: only a limit was reported; the forecaster's own chance of this, stated with the estimate: 65%; the middle value sits exactly at the limit.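

In this assay, the change to 2-(1H-imidazol-1-yl)ethyl gives an at least 17-fold higher number from compound 3 to compound 4 (1.25 log units; beyond the scatter), so among the compounds shown a number is still seen only with 3-(piperidin-1-yl)propyl. Compound 4 carries the phenyl on the amide-type nitrogen, yet that phenyl does not bring a readable number with this chain. The steps to compound 4 from compound 1 and compound 2 cannot be read, because both ends of each sit at a limit: the limit of > 100000 nM in this assay, at which 3 of the 4 values shown sit.

Going by these compounds, this step changes ring and chain together, so their shares stay open. On these data alone, how 2-(piperidin-1-yl)ethyl, 3-(1H-imidazol-1-yl)propyl or a morpholine or dimethylamino group on the propyl chain would read also stays open.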